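The source may hold more compounds than are shown below. What is called first, only, known or untested is meant among the compounds shown, and "the series" means these compounds.

The measured compounds:
compound 1, `O=C(Nc1cccc(-n2cc(-c3ccncc3)c(-c3cc(O)cc(Cl)c3)n2)c1)Nc1ccc(Cl)c(C(F)(F)F)c1`, 94%;
compound 2, `COc1cc(Cl)cc(-c2nn(-c3cccc(NC(=O)Nc4ccc(Cl)c(C(F)(F)F)c4)c3)cc2-c2ccncc2)c1`, 91%;
compound 3, `COc1cc(Cl)cc(-c2nn(-c3cccc(NC(=O)Nc4cc(C(F)(F)F)cc(C(F)(F)F)c4)c3)cc2-c2ccncc2)c1`, 91%.

Among the compounds with values here, in a functional assay on K562 cells (Homo sapiens) for inhibition, read by sulforhodamine B assay, with a stated time of 48 h, tested at 0.1 uM (a higher number here means a weaker effect of the compound at the concentration tested, a lower number a stronger effect), compound 2 stands level with compound 3 at the digits reported, and its only direct neighbour among the measured compounds is compound 1: a number 3 percentage points lower from compound 1 to compound 2 (within the scatter). The three numbers lie within the scatter of one another, so none can be called the weakest or the strongest.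

Compound 4, `COc1cc(Cl)cc(-c2nn(-c3cccc(NC(=O)c4cccc(C(F)(F)F)c4)c3)cc2-c2ccncc2)c1`, differs from compound 2 at the carbonyl carbon: 3-(trifluoromethyl)phenyl in place of (4-chloro-3-(trifluoromethyl)phenyl)amino on a carbonyl carbon. Within the data shown here, no measured step touches this part of the molecule; the one step known, from hydrogen to methyl on the oxygen, is elsewhere and lies within the scatter. The account therefore expects for compound 4 a value of 90%, between 75% and 100%, a step of a number 1 percentage points lower from compound 2 to compound 4 (within the scatter), not beyond the scatter.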

Compound 4, a percentage reported as activity, at one concentration (the size of the read-out at that concentration, not a potency): 112%
For compound 4 the middle estimate is 22 percentage points below the measured one; the measured number lies above the stated range.
By their numbers in this assay, from the lowest: compounds 2, 3 and 1 (each within the scatter of the next); then compound 4.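

In this assay, within the data shown here, the carbonyl carbon proves sensitive to change: 3-(trifluoromethyl)phenyl in place of (4-chloro-3-(trifluoromethyl)phenyl)amino gives a number 21 percentage points higher from compound 2 to compound 4 (beyond the scatter) and so a weaker effect, the first step here beyond the scatter. This single change removes the amino nitrogen, with its hydrogen-bond donor, and the chlorine together, so their shares cannot be separated. Nothing available explains the step. On these data alone, it remains open whether (3-(trifluoromethyl)phenyl)amino, which keeps the nitrogen without the chlorine, or 4-chloro-3-(trifluoromethyl)phenyl, which keeps the chlorine without the nitrogen, would stay level with compound 2 on this carbonyl carbon.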